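Capping the Second Phenol of a Biaryl Dichlorobenzyl Ether

A few compounds are considered here, and "the series" means these few. Any claim that something is new, unique, unknown or untested is made for them only; others in the source may bear on it.

Compound 1, `C=CCc1ccc(OCc2ccccc2)c(-c2ccc(O)c(CC=C)c2)c1`, 22300 nM
Compound 2, `C=CCc1ccc(O)c(-c2ccc(OCc3c(Cl)cccc3Cl)c(CC=C)c2)c1`, 11500 nM
Compound 3, `C=CCc1ccc(OCc2ccc(Cl)cc2Cl)c(-c2ccc(OCc3ccc(Cl)cc3Cl)c(CC=C)c2)c1`, the limit > 50000 nM

In a functional assay on MCF7 cells (Homo sapiens) for inhibition, read by MTT assay, with a stated time of 72 h (a lower number here means a stronger inhibitor, a higher number a weaker inhibitor), compound 1 gives 22300 nM. Compound 2 gives 11500 nM, the lowest of the two numbers, though its gap to compound 1 lies within the scatter. Compound 3 reaches only a limit, > 50000 nM, in this assay. Compound 4, `C=CCc1ccc(OCc2c(Cl)cccc2Cl)c(-c2ccc(OCc3c(Cl)cccc3Cl)c(CC=C)c2)c1`, differs from compound 2 by 2,6-dichlorobenzyl in place of hydrogen on an oxygen on an aromatic ring.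

For the measured compounds named here, no measured pair shows this step. Compound 3, with both oxygens capped, sits at the limit of > 50000 nM in this assay, at which 1 of the 3 values shown sits, so a weakening in this assay is expected, of moderate size. Compound 4 is expected to give 40000 nM, in the range 15000 nM to 100000 nM. The expected step is a 3.5-fold higher number from compound 2 to compound 4 (0.54 log units; beyond the scatter).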

Compound 4, half-maximal inhibitory concentration: > 50000 nM
Compound 4 was reported as a limit; the forecaster's own chance of this, stated with the estimate: 45%; middle value at least 1.2-fold (0.09 log units) from the limit.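

In this assay, the change from hydroxy to (2,6-dichlorobenzyl)oxy on this oxygen now has a measured pair, which gives an at least 4.3-fold higher number from compound 2 to compound 4 (0.63 log units; beyond the scatter). The reading for compound 4 is a limit and not a number. With both oxygens capped, compound 3 and compound 4 share one reading: the limit of > 50000 nM in this assay, at which 2 of the 4 values shown sit. The compounds shown leave open whether a much smaller cap on this oxygen, such as methyl, would keep the value of compound 2. They also leave open how a chain ending in an amine or a carboxylic acid would read here.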